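Extending the Alkyl Chain on the Shared Triazole Core

The source may report more compounds than this note shows. Statements on the series, on what has been measured and on what is new or still open speak of the compounds shown alone.

Measured compounds:
- compound 1 `COC(=O)c1nc(C)n(-c2ccccc2C(F)(F)F)n1` gives 6130 nM in a functional assay on NCI-H226 cells (Homo sapiens) for inhibition, read by MTT assay, with a stated time of 72 h; on this read-out lower numbers stand for stronger inhibition of growth and higher numbers for weaker inhibition of growth
- compound 2 `CCc1nc(C(=O)OC)nn1-c1ccc(F)cc1` gives 71300 nM in this assay

Of the two measured compounds, compound 2 stands at the higher number, meaning weaker inhibition of growth; its nearest neighbour, compound 1, sits well below it, and the gap between them is beyond the usual scatter. The two compounds differ in more than one place, so nothing can be read into which change accounts for that gap.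

Compound 3 `CCCCc1nc(C(=O)OC)nn1-c1ccc(F)cc1` has not yet been measured. It differs from compound 2 in one respect: ethyl in place of hydrogen on a saturated chain carbon, two bonds along the chain from an aromatic carbon. Among the measured compounds shown here, no comparable step between measured compounds exists here, so there is no direct guide to its size.

Given that compound 2 gives 71300 nM, the chain extension is expected to bring only a modest change, if any, with a slight lean toward a lower number; the step of a 1.8-fold lower number from compound 2 to compound 3 (0.25 log units; within the scatter) is an estimate and could well fall within the scatter. Compound 3 is therefore expected to give 40000 nM, with a range from 10000 nM to 150000 nM.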

Compound 3, concentration for 50% growth inhibition: 6400 nM
Compound 3: middle estimate off by 6.3-fold (0.80 log units), on the high side; measured number outside the range, below it.
By their numbers in this assay, from the lowest: compounds 1 and 3 (each within the scatter of the next); then compound 2.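

Extending ethyl to butyl gives an 11-fold lower number from compound 2 to compound 3 (1.05 log units; beyond the scatter) in this assay and is the first change here that can be read on its own, since the rest of the molecule stays the same. It shows that this saturated chain is not a neutral place on the shared core: adding ethyl in place of hydrogen, two bonds along the chain from an aromatic carbon, goes with clearly stronger inhibition of growth, a step beyond the usual scatter. No measurement shown here gives a reason for this gain, so the step records what happens and not why it happens.

A single step cannot show whether the number keeps falling with chain length, levels off or turns back up, and a hexyl chain, a branched isopropyl group or a butyl chain ending in an amine or a carboxylic acid would each test that further. As far as these compounds go, compound 1 differs from the other two compounds in more than one place, so the separate contributions of its methyl group and its trifluoromethyl-bearing ring remain unknown.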